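The source may hold more compounds than are shown below. What is called first, only, known or untested is meant among the compounds shown, and "the series" means these compounds.

Of the compounds shown here, two with the same core have been measured in a functional assay on L1210 cells (Mus musculus) for cytotoxicity; a higher number here means that more compound is needed for the effect, a lower number that less compound is needed. Among the measured compounds shown here, compound 1 (`CCC(O)C1=CC(=O)c2c(OC)ccc(OC)c2C1=O`) gives 0.516 ug/mL and compound 2 (`CCCCCC(O)C1=CC(=O)c2c(OC)ccc(OC)c2C1=O`) gives 0.378 ug/mL, so compound 2 stands within the usual scatter of the only other number available. Compound 3 (`CCCCC(O)C1=CC(=O)c2c(OC)ccc(OC)c2C1=O`) has not yet been measured. Its difference from compound 2 is small: hydrogen in place of methyl on a saturated chain carbon, five bonds along the chain from a double-bonded ring carbon and an oxygen on a saturated carbon. In words, this is hydrogen in place of methyl on a saturated chain carbon, five bonds along the chain from a double-bonded ring carbon and an oxygen on a saturated carbon. The chain of compound 3 is therefore shorter than that of compound 2 and longer than that of compound 1. For the measured compounds named here, only one measured step bears on this change, and it involves a larger change in the same chain: a 1.4-fold lower number from compound 1 to compound 2 (0.14 log units; within the scatter). With so little movement across that wider change, no shift beyond the scatter is expected in this assay. The estimated change is a 1.2-fold higher number from compound 2 to compound 3 (0.07 log units; within the scatter). For compound 3 the expected value is 0.44 ug/mL, with an estimated range of 0.25 ug/mL to 0.75 ug/mL.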

Compound 3, concentration for half-maximal effect: 0.412 ug/mL
Beside the measured number, compound 3's estimate is 1.1-fold (0.03 log units) above it; measured number inside the range.
By their numbers in this assay, from the lowest: compounds 2, 3 and 1 (each within the scatter of the next).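

In this assay, the result of a 1.1-fold higher number from compound 2 to compound 3 (0.04 log units; within the scatter) comes from putting hydrogen in place of methyl on a saturated chain carbon, five bonds along the chain from a double-bonded ring carbon and an oxygen on a saturated carbon. The second new step, a 1.3-fold lower number from compound 1 to compound 3 (0.10 log units; within the scatter), shows that the same holds when compound 3 is set against the shorter chain, so a third chain length now adds two more steps on this core and all three steps among these compounds lie within the scatter. Chain length at this position therefore makes no readable difference among compounds 1, 2 and 3, and nothing measured here offers an explanation for that.

From the compounds shown here alone, these compounds span only a narrow run of straight chains, so it remains open whether a much longer chain, such as octyl or decyl, or a branched chain such as isopropyl, would give a number beyond the scatter. Going by these compounds, it is also open what a phenyl ring at the end of the chain, or an amine in place of the oxygen on the saturated carbon, would do in this assay.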